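Replacing an Aromatic Ring with an Open-Chain Amidine Group

A few compounds are considered here, and "the series" means these few. Any claim that something is new, unique, unknown or untested is made for them only; others in the source may bear on it.

Compound 1 `c1cnc(NCCCNCC2CCc3ccccc3O2)nc1`: 1.59 nM
Compound 2 `Clc1ccc(NCCCNCC2CCc3ccccc3O2)nn1`: 2 nM

In an assay on isolated protein (Bos taurus) with 5-hydroxytryptamine receptor 1D (Homo sapiens) as the target (on this read-out lower numbers stand for stronger inhibition and higher numbers for weaker inhibition), compound 1 gives 1.59 nM, and compound 2 gives 2 nM. For the measured compounds named here, the single step measured so far, a 1.3-fold higher number from compound 1 to compound 2 (0.10 log units; within the scatter), exchanged one aromatic ring for another, so compound 2 stands within the scatter of compound 1, the only other number available.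

Compound 3 `CC(C)/N=C(\N)NNCCCNCC1CCc2ccccc2O1` differs from compound 2 by a group of 7 heavy atoms (4 carbon, 3 nitrogen; no ring) in place of a group of 7 heavy atoms (4 carbon, 2 nitrogen, 1 chlorine; one six-membered aromatic ring with 2 hetero atoms), on an amine nitrogen. Going by the values given here, no measured step bears on this kind of change: the one comparison in hand kept a six-membered aromatic ring in place, whereas here the ring is given up for an open-chain group. That comparison gave no movement beyond the scatter, but it offers no guide to the present exchange. A moderate weakening is therefore expected, a 4.0-fold higher number from compound 2 to compound 3 (0.60 log units; beyond the scatter), with wide uncertainty. For compound 3 in this assay the estimate is 8 nM, ranging from 1.5 nM to 40 nM.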

Compound 3, half-maximal inhibitory concentration: 3.16 nM
Compound 3: the middle estimate sits 2.5-fold (0.40 log units) above what was measured; low and high end bracket the measured number.
By their numbers in this assay, from the lowest: compounds 1, 2 and 3 (each within the scatter of the next).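

With the ring given up, this assay shows a 1.6-fold higher number from compound 2 to compound 3 (0.20 log units; within the scatter) and a 2.0-fold higher number from compound 1 to compound 3 (0.30 log units; within the scatter) and so no movement beyond the scatter on either comparison. Compounds 1 and 2 both carried a six-membered aromatic ring with 2 hetero atoms on the amine nitrogen, whereas compound 3 shows that, among these three compounds, such a ring is not required there for a number in this range. Nothing measured here explains this result.

On these data alone, whether a urea, a plain amine or a phenyl ring on this nitrogen would stay in the same range remains open. As far as these compounds go, it is also open which part of the open-chain group counts, since its double bond, its hydrogen-bond donors and its branched carbon end all entered in the same step.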